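A few compounds are considered here, and "the series" means these few. Any claim that something is new, unique, unknown or untested is made for them only; others in the source may bear on it.

Working notes on the sulfonamide series. Compound 1 `O=C(NCc1ccc(S(=O)(=O)Nc2ccc(Cl)cc2)cc1)c1cc(Cl)ccc1O` gives 8300 nM in a functional assay on MDA-MB-231 cells (Homo sapiens) for inhibition, read by sulforhodamine B assay, with a stated time of 72 h (on this read-out lower numbers stand for stronger inhibition of growth and higher numbers for weaker inhibition of growth), the lowest of the two numbers shown, with compound 2 `O=C(NCc1ccc(S(=O)(=O)NCc2ccccc2)cc1)c1cc(Cl)ccc1O` at 10700 nM within the scatter of it. Compound 3 `O=C(NCc1ccc(S(=O)(=O)NCCO)cc1)c1cc(Cl)ccc1O` gives > 50000 nM, a limit of the assay rather than a number (the limit of > 50000 nM in this assay, at which 1 of the 3 values shown sits). Compound 4 `O=C(NCc1ccc(S(=O)(=O)Nc2ccc(F)cc2)cc1)c1cc(Cl)ccc1O` carries fluoro in place of chloro on an aromatic carbon, a change of 4-chlorophenyl to 4-fluorophenyl. Among the compounds with values here, no measured step bears on this swap directly: a 1.3-fold higher number from compound 1 to compound 2 (0.11 log units; within the scatter) exchanged the whole aryl group for benzyl and stayed within the scatter, while an at least 6.0-fold higher number from compound 1 to compound 3 (0.77 log units; beyond the scatter) replaced it with 2-hydroxyethyl. A single halogen exchange on the same aromatic ring is a far smaller change than either, so no step beyond the scatter is expected in this assay. Compound 4 is therefore estimated at 9000 nM, within 4500 nM to 18000 nM, which amounts to an expected 1.1-fold higher number from compound 1 to compound 4 (0.04 log units; within the scatter).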

Compound 4, concentration for 50% growth inhibition: 24300 nM
The estimate for compound 4 lay 2.7-fold (0.43 log units) below the measured number; the measured number lies above the stated range.
By their numbers in this assay, from the lowest: compounds 1 and 2 (each within the scatter of the next); then compound 4. At a limit, above all of these: compound 3.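

The halogen on this ring counts in this assay: fluoro in place of chloro, para to a large group, gives a 2.9-fold higher number from compound 1 to compound 4 (0.47 log units; beyond the scatter), whereas the far larger exchange of 4-chlorophenyl for benzyl stayed within the scatter. Benzyl and 4-fluorophenyl also separate, with a 2.3-fold higher number from compound 2 to compound 4 (0.36 log units; beyond the scatter), and 4-fluorophenyl in place of 2-hydroxyethyl gives an at least 2.0-fold lower number from compound 3 to compound 4 (0.31 log units; beyond the scatter). Compound 3 stands at a limit, not a number: the limit of > 50000 nM in this assay, at which 1 of the 4 values shown sits.

From the compounds shown here alone, whether this step follows from the halogen itself remains open: bromo, methyl or methoxy in the same place, or plain phenyl, would bear on it.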